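A few compounds are considered here, and "the series" means these few. Any claim that something is new, unique, unknown or untested is made for them only; others in the source may bear on it.

Measured compounds in a functional assay on SMMC-7721 cells (Homo sapiens) for cytotoxicity, read by MTT assay, with a stated time of 72 h; on this read-out higher numbers stand for weaker inhibition and lower numbers for stronger inhibition:
compound 1 `CCN(C)C(=O)N1CCN(C(=S)SCc2cn(Cc3ccccc3F)nn2)CC1`, 19700 nM
compound 2 `CCN(C)C(=O)N1CCN(C(=S)SCc2cn(Cc3ccc(F)cc3)nn2)CC1`, 23700 nM
compound 3 `CCNC(=O)N1CCN(C(=S)SCc2cn(Cc3ccc(C)cc3)nn2)CC1`, > 128000 nM, which is a limit of the assay and not a number

Compound 3 thus gives only a limit in this assay, (the limit of > 128000 nM in this assay, at which 1 of the 3 values shown sits), so its place among the measured compounds cannot be fixed more closely. Compound 4 `CCN(C)C(=O)N1CCN(C(=S)SCc2cn(Cc3ccc(C)cc3)nn2)CC1` differs from it by methyl in place of hydrogen on an amide-type nitrogen. Going by the values given here, no measured step covers this change. Among the compounds with values here, the only measured step, a 1.2-fold higher number from compound 1 to compound 2 (0.08 log units; within the scatter), concerns the fluorophenyl position and lies within the scatter; compounds 1 and 2, which carry the ethyl(methyl)carbamoyl group, both give measurable numbers in this assay. On this basis compound 4 is expected to give a measurable number, the expected step being an at least 3.6-fold lower number from compound 3 to compound 4 (0.56 log units; beyond the scatter). The estimate for compound 4 is 35000 nM, within 12000 nM to 128000 nM.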

Compound 4, half-maximal inhibitory concentration: > 128000 nM
Compound 4 ended at the assay's limit; the forecaster's own chance of this, stated with the estimate: 25%; at least 3.6-fold (0.56 log units) between middle value and limit.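

In this assay compound 4 shows that the ethyl(methyl)carbamoyl group does not by itself secure a measurable number. Methyl in place of fluoro on an aromatic carbon gives an at least 5.4-fold higher number from compound 2 to compound 4 (0.73 log units; beyond the scatter) and 4-methylphenyl in place of 2-fluorophenyl gives an at least 6.4-fold higher number from compound 1 to compound 4 (0.81 log units; beyond the scatter). The step for methyl in place of hydrogen on the amide-type nitrogen cannot be read, as both compounds stand at a limit of the assay: the limit of > 128000 nM in this assay, at which 2 of the 4 values shown sit.

The compounds shown leave open whether chloro, methoxy or an amine on that aromatic carbon would give a measurable number. They also leave open how the ethylcarbamoyl group reads alongside a fluorophenyl group.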